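Working notes: from compound 3 to compound 4

The compounds below may be only part of what the source reports. "The series", "measured", "known", "first", "only" and "open" are said of these compounds alone.

Values in a functional assay on PC-3 cells (Homo sapiens) for cytotoxicity, read by colorimetric assay (a lower number here means a stronger inhibitor, a higher number a weaker inhibitor), so far:
- compound 1 `O=C(NO)c1ccc(CN2C(=O)/C(=C3\Nc4ccccc4\C3=N/O)c3cc(Cl)ccc32)cc1` gives 50 nM
- compound 2 `O=C(NO)c1ccc(CN2C(=O)/C(=C3\Nc4ccccc4\C3=N/O)c3cc(F)ccc32)cc1` gives 50 nM
- compound 3 `O=C(/C=C/c1ccc(CN2C(=O)/C(=C3\Nc4ccccc4\C3=N/O)c3cc(Br)ccc32)cc1)NO` gives 90 nM

The value of compound 3 lies within the scatter of those of compound 1 and compound 2. Compound 4 `O=C(NO)c1ccc(CN2C(=O)/C(=C3\Nc4ccccc4\C3=N/O)c3cc(Br)ccc32)cc1` differs from compound 3 as follows: hydroxycarbamoyl in place of 2-(hydroxycarbamoyl)ethenyl on an aromatic carbon. Going by the values given here, no measured step makes this exchange. Among the compounds with values here, the one measured step in a single place, no change at the digits printed from compound 1 to compound 2 (within the scatter), concerns the halogen only. It shows no change beyond the scatter among compounds already carrying hydroxycarbamoyl. No step beyond the scatter is therefore expected in this assay. The expected step is a 1.8-fold lower number from compound 3 to compound 4 (0.26 log units; within the scatter). Compound 4 is estimated at 50 nM, with an expected range of 25 nM to 110 nM.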

Compound 4, half-maximal inhibitory concentration: 50 nM
The estimate for compound 4 equals the measured number at the digits printed; measured number inside the range.
By their numbers in this assay, from the lowest: compounds 1, 2, 4 and 3 (each within the scatter of the next).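

In this assay, going by these compounds alone, the first reading of hydroxycarbamoyl in place of 2-(hydroxycarbamoyl)ethenyl on this aromatic carbon gives a step within the scatter (a 1.8-fold lower number from compound 3 to compound 4 (0.26 log units; within the scatter)), so this exchange, with the bromo group held fixed, does not separate the two compounds. Among the compounds carrying hydroxycarbamoyl, bromo now also stays within the scatter of fluoro (no change at the digits printed from compound 2 to compound 4 (within the scatter)) and of chloro (no change at the digits printed from compound 1 to compound 4 (within the scatter)). No available evidence bears on these results.

As far as these compounds go, whether fluoro or chloro behaves the same way alongside 2-(hydroxycarbamoyl)ethenyl remains open. So does the outcome of replacing hydroxycarbamoyl at this carbon with a carboxylic acid, an amine or a longer chain.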